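Alkyne to alkene with a smaller ring at the chain end

The compounds below may be only part of what the source reports. "The series", "measured", "known", "first", "only" and "open" are said of these compounds alone.

The measured compounds:
Compound 1, `COC(=O)CC/C=C\CC[C@H]1C(=O)C[C@@H](O)[C@@H]1/C=C/C[C@@](C)(O)/C=C/C1=CCCC1`, gives 0.00002 mg/kg in a functional assay on the whole organism (stomach) with Canis familiaris (Canis lupus familiaris) as the target; a higher number here means that more compound is needed for the effect, a lower number that less compound is needed.
Compound 2, `COC(=O)CC/C=C\CC[C@H]1C(=O)C[C@@H](O)[C@@H]1/C=C/CC(C)(O)CCC1CC1`, gives 0.00009 mg/kg in this assay.
Compound 3, `COC(=O)CC/C=C\CC[C@H]1C(=O)C[C@@H](O)[C@@H]1/C=C/C[C@@](C)(O)C#CC1=CCCC1`, gives 0.0028 mg/kg in this assay.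

Compound 3 stands highest of the three, so it needs the most compound for the effect: compound 2 is nearest, compound 1 furthest, and both gaps lie beyond the scatter. Compound 4, `COC(=O)CC/C=C\CC[C@H]1C(=O)C[C@@H](O)[C@@H]1/C=C/C[C@@](C)(O)/C=C/C1CC1`, differs from compound 3 in one place: 2-cyclopropylethenyl in place of 2-(cyclopent-1-en-1-yl)ethynyl on a saturated chain carbon bound to an oxygen on a saturated carbon and two saturated chain carbons.

Going by the values given here, two measured steps bear on this. a 140-fold higher number from compound 1 to compound 3 (2.15 log units; beyond the scatter) shows that the triple bond in place of the double bond raised the number greatly; reversing it in compound 4 should therefore lower the number by a large amount. a 4.5-fold higher number from compound 1 to compound 2 (0.65 log units; beyond the scatter) shows that the cyclopropyl-bearing chain in place of the cyclopentenyl-bearing chain raised the number modestly. Compound 4 combines the double bond with the cyclopropyl, so a large drop from compound 3, tempered somewhat, is expected: a 56-fold lower number from compound 3 to compound 4 (1.75 log units; beyond the scatter). Compound 4 is estimated at 0.00005 mg/kg in this assay, within 0.00001 mg/kg to 0.0003 mg/kg.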

Compound 4, dose for half-maximal effect: 0.0001 mg/kg
For compound 4 the middle estimate is 2.0-fold (0.30 log units) below the measured one; the measured number falls inside the stated range.
By their numbers in this assay, from the lowest: compound 1; then compounds 2 and 4 (each within the scatter of the next); then compound 3.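

In this assay the ring swap alone, with the double bond kept, gives a 5.0-fold higher number from compound 1 to compound 4 (0.70 log units; beyond the scatter) and so stays modest, while the full change gives a 28-fold lower number from compound 3 to compound 4 (1.45 log units; beyond the scatter) and is large. Most of the drop on leaving 2-(cyclopent-1-en-1-yl)ethynyl therefore goes with losing the triple bond rather than with changing the ring. With cyclopropyl at the chain end, the double bond makes no readable difference, as a 1.1-fold higher number from compound 2 to compound 4 (0.05 log units; within the scatter) separates the saturated 3-cyclopropyl-1-hydroxy-1-methylpropyl from 3-cyclopropyl-1-hydroxy-1-methylprop-2-en-1-yl.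

As far as these compounds go, whether a triple bond would raise the number as sharply with cyclopropyl at the chain end stays open, as does how a phenyl or cyclohexyl ring there would behave. Nothing shown here explains why these differences arise.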